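The source may report more compounds than this note shows. Statements on the series, on what has been measured and on what is new or still open speak of the compounds shown alone.

Measured so far in an assay on isolated protein for inhibition of Dopamine beta-hydroxylase (Rattus norvegicus); on this read-out higher numbers stand for weaker inhibition and lower numbers for stronger inhibition: compound 1 `COc1ccc(Cn2cc[nH]c2=S)cc1` gives 204000 nM; compound 2 `COc1ccccc1Cn1cc[nH]c1=S` gives 74100 nM; compound 3 `Cc1cc(Cn2cc[nH]c2=S)ccc1O` gives 49000 nM.

Compound 2 holds the second highest of the three numbers. Its gap to compound 3 lies within the scatter, so no order between those two is claimed; its gap to compound 1 lies beyond the scatter, with compound 1 the higher. Compound 4 `Cc1ccccc1Cn1cc[nH]c1=S` differs from compound 2 by methyl in place of methoxy on an aromatic carbon. Within the data shown here, no measured pair shows this exchange, so the expectation rests on compound 2 alone. The expected step in this assay is a 1.2-fold lower number from compound 2 to compound 4 (0.09 log units; within the scatter), small, without a clear direction, and not beyond the scatter. Compound 4 is estimated at 60000 nM, in a range from 20000 nM to 200000 nM.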

Compound 4, half-maximal inhibitory concentration: 339000 nM
Compound 4: middle estimate off by 5.7-fold (0.75 log units), on the low side; measured number outside the range, above it.
By their numbers in this assay, from the lowest: compounds 3 and 2 (each within the scatter of the next); then compounds 1 and 4 (each within the scatter of the next).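

In this assay, methyl in place of methoxy on this aromatic carbon, ortho to a group of 7 heavy atoms, gives a 4.6-fold higher number from compound 2 to compound 4 (0.66 log units; beyond the scatter). Among these compounds, this is the first single-place exchange, and it shows that the group at this position can move the number, with methoxy the better of the two here. No measurement shown gives a reason for the step.

Open, going by these compounds, is where a hydroxy group, an amine or an ethoxy group at this position would fall relative to methoxy and methyl. Also open, on these data alone, is whether the same exchange elsewhere on the ring gives a step of similar size.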